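Triazole aryl substituent on a phenolic core: trifluoromethyl to fluoro

The source may hold more compounds than are shown below. What is called first, only, known or untested is meant among the compounds shown, and "the series" means these compounds.

Compound 1 `C=C1C(=O)[C@]23C[C@@]1(O)CC[C@H]2c1ccc(O)c(C)c1[C@@H]3Cn1cc(-c2ccc(C(F)(F)F)cc2)nn1` carries a phenol on its core and a 4-(trifluoromethyl)phenyl group on the triazole. For the measured compounds named here, in a functional assay on MCF7 cells (Homo sapiens) for cytotoxicity, read by MTT assay, with a stated time of 4 days (on this read-out higher numbers stand for weaker inhibition and lower numbers for stronger inhibition), compound 1 gives 1840 nM, the only numeric value among the two compounds measured so far. Compound 2 `Cc1ccc(S(=O)(=O)Oc2ccc3c(c2C)[C@H](Cn2cc(-c4ccc(Br)cc4)nn2)[C@@]24CC(=O)[C@@](C)(CC[C@@H]32)C4)cc1`, with a sulfonate in place of the phenol and a 4-bromophenyl group on the triazole, returns only a limit in this assay, > 20000 nM. That limit, (the limit of > 20000 nM in this assay, at which 1 of the 2 values shown sits), is one of the two values obtained here; it gives no number to compare with compound 1 and is left aside for the step below.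

Compound 3 `C=C1C(=O)[C@]23C[C@@]1(O)CC[C@H]2c1ccc(O)c(C)c1[C@@H]3Cn1cc(-c2ccc(F)cc2)nn1` has not been measured in this assay. It differs from compound 1 by fluoro in place of trifluoromethyl on an aromatic carbon, para to a large group on the aromatic ring bound to the triazole. Going by the values given here, no measured pair shows this change; the step is expected to be modest, toward weaker inhibition, a 1.9-fold higher number from compound 1 to compound 3 (0.28 log units; within the scatter). Compound 3 is therefore estimated at 3500 nM in this assay, with a range from 1200 nM to 10000 nM.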

Compound 3, half-maximal inhibitory concentration: 1700 nM
Compound 3: middle estimate off by 2.1-fold (0.31 log units), on the high side, within the range that was stated.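

In this assay, fluoro in place of trifluoromethyl on an aromatic carbon, para to a large group, gives a 1.1-fold lower number from compound 1 to compound 3 (0.03 log units; within the scatter). For the compounds shown here, this is the first pair that differs in one place, and it shows that with the shared core held constant, 4-(trifluoromethyl)phenyl and 4-fluorophenyl on the triazole are not told apart on this read-out, even though the substituent goes from 4 heavy atoms to 1 heavy atom. Nothing measured here bears on why the two compounds read alike.

On these data alone, only these two substituents are compared at this position, so it remains open whether a more different group there, such as an amine, a carboxylic acid or a longer alkyl chain, would also leave the number within the scatter. For compound 2 the value of > 20000 nM is a limit and not a number, and compound 2 differs from compound 1 in more than one place, so it gives no reading on the phenol or on the bromo substituent.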